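The source may hold more compounds than are shown below. What is called first, only, known or untested is meant among the compounds shown, and "the series" means these compounds.

compound 1 `CCC[S+]([O-])CCCCN=C=S`: 10700 nM
compound 2 `[O-][S+](CCCCN=C=S)Cc1ccccc1`: 7410 nM
compound 3 `O=[N+]([O-])c1ccc(C[S+]([O-])CCCCN=C=S)cc1`: 14400 nM

All three numbers come from a functional assay on A549 cells (Homo sapiens) for cytotoxicity, read by MTT assay, with a stated time of 72 h; on this read-out lower numbers stand for stronger inhibition and higher numbers for weaker inhibition. Compound 3, which carries a nitro group on its aromatic ring, gives 14400 nM. That number lies within the usual scatter of the numbers for compound 1 and compound 2, so these three compounds cannot be ranked.

Compound 4 `COc1ccc(C[S+]([O-])CCCCN=C=S)cc1` differs from compound 3 in one place: methoxy in place of nitro on an aromatic carbon. In words, this is methoxy in place of nitro on an aromatic carbon, para to a large group.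

Among the measured compounds shown here, only one measured step involves a change at an aromatic carbon: a 1.9-fold higher number from compound 2 to compound 3 (0.29 log units; within the scatter). Putting nitro in place of hydrogen therefore shifted the number by no more than the scatter. For the measured compounds named here, no measured compound carries a methoxy group, so the data offer no direct evidence on it. Compound 1, which has no aromatic ring, gives 10700 nM, also within the scatter of the other two.

On this basis, no step beyond the scatter is expected in this assay, and the expected change is a 1.4-fold lower number from compound 3 to compound 4 (0.16 log units; within the scatter). For compound 4, the estimated value is 10000 nM, with an expected range from 5500 nM to 18000 nM.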

Compound 4, half-maximal inhibitory concentration: 32600 nM
For compound 4 the middle estimate is 3.3-fold (0.51 log units) below the measured one, outside the stated range (above it).
By their numbers in this assay, from the lowest: compounds 2, 1 and 3 (each within the scatter of the next); then compound 4.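

Among the compounds shown here, until this result, the only change on the aromatic ring had stayed within the usual scatter in this assay but methoxy in place of nitro on this carbon, para to a large group, gives a 2.3-fold higher number from compound 3 to compound 4 (0.35 log units; beyond the scatter) and so weakens the measured cytotoxicity. Methoxy in place of hydrogen on the same carbon gives a 4.4-fold higher number from compound 2 to compound 4 (0.64 log units; beyond the scatter) which shows that methoxy stands apart from both the nitro group and the bare ring, whereas those two remain within the scatter of each other. This carbon is therefore not indifferent to what it carries in these compounds, although no measurement shown here accounts for the difference between methoxy and the other two.

The compounds shown leave open whether this loss belongs to methoxy alone or would also appear with an amine, a hydroxyl group or a chlorine atom on the same carbon. They also leave open whether a methoxy group on another carbon of the ring, or a longer chain in place of methoxy, would give a similar number.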